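Swapping hydroxymethyl for 3-bromoprop-1-en-1-yl

A few compounds are considered here, and "the series" means these few. Any claim that something is new, unique, unknown or untested is made for them only; others in the source may bear on it.

Measured in a functional assay on KYSE-450 cells (Homo sapiens) for inhibition, read by MTT assay, with a stated time of 48 h; on this read-out higher numbers stand for weaker inhibition and lower numbers for stronger inhibition:
Compound 1 `COCC(=O)N(Cc1ccc(OC)c(O)c1)c1cc(OC)c(OC)c(OC)c1` gives 460 nM
Compound 2 `CC/C=C/C(=O)N(Cc1ccc(OC)c(O)c1)c1cc(OC)c(OC)c(OC)c1` gives 72 nM
Compound 3 `COc1ccc(CN(C(=O)CO)c2cc(OC)c(OC)c(OC)c2)cc1O` gives 370 nM

Compound 3 sits within the scatter of compound 1, and well above compound 2, as a 5.1-fold higher number from compound 2 to compound 3 (0.71 log units; beyond the scatter) shows. Compound 4 `COc1ccc(CN(C(=O)/C=C/CBr)c2cc(OC)c(OC)c(OC)c2)cc1O` carries 3-bromoprop-1-en-1-yl in place of hydroxymethyl on a carbonyl carbon. The closest evidence is the but-1-en-1-yl group of compound 2, also a chain with a double bond. Its effect appears in a 6.4-fold lower number from compound 1 to compound 2 (0.81 log units; beyond the scatter) and, in reverse, in the step above. Among the compounds with values here, no measured compound contains bromine, so the outcome is uncertain. The expected change is a 4.6-fold lower number from compound 3 to compound 4 (0.67 log units; beyond the scatter), a modest move towards stronger inhibition. Compound 4 is estimated at 80 nM, with an expected range of 25 nM to 260 nM.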

Compound 4, half-maximal inhibitory concentration: 100 nM
The estimate for compound 4 lay 1.3-fold (0.10 log units) below the measured number; low and high end bracket the measured number.
By their numbers in this assay, from the lowest: compounds 2 and 4 (each within the scatter of the next); then compounds 3 and 1 (each within the scatter of the next).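

On the carbonyl carbon, 3-bromoprop-1-en-1-yl gives stronger inhibition in this assay than hydroxymethyl (a 3.7-fold lower number from compound 3 to compound 4 (0.57 log units; beyond the scatter)) or methoxymethyl (a 4.6-fold lower number from compound 1 to compound 4 (0.66 log units; beyond the scatter)). Bromo in place of methyl on the chain makes no clear difference (a 1.4-fold higher number from compound 2 to compound 4 (0.14 log units; within the scatter)), so two chains with a double bond now stand apart from compound 1 and compound 3. No measured evidence here explains this result. Still open, from the compounds shown here alone, is whether the double bond itself matters, which a saturated butyl chain would test. Going by these compounds, it is also open how an amine or a carboxylic acid at the chain end would behave.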